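The source may report more compounds than this note shows. Statements on the series, on what has been measured and on what is new or still open speak of the compounds shown alone.

The measured compounds so far:

Compound 1, `CC(C)C(Cc1ncc[nH]1)c1ccc(-c2ccc3cccc(F)c3c2)[nH]c1=O`: in an assay on CHO cells for displacement of a labelled ligand from prostaglandin E2 receptor EP3 subtype (Homo sapiens), read by radioligand binding (a lower number here means a stronger inhibitor, a higher number a weaker inhibitor), compound 1 gives 11 nM.
Compound 2, `CC(C)C(Nc1nnc[nH]1)c1ccc(-c2ccc3cccc(F)c3c2)[nH]c1=O`: in this assay compound 2 gives 22 nM.

Going by the values given here, of these two numbers, compound 2 has the higher one; its only neighbour is compound 1, and the step of a 2.0-fold higher number from compound 1 to compound 2 (0.30 log units; within the scatter) lies within the scatter, so the two compounds cannot be told apart on this evidence. The next compound, compound 3, `CC(C)C(c1ccc(-c2ccc3cccc(F)c3c2)[nH]c1=O)N1CCNC1=O`, differs from compound 2 in one place: 2-oxoimidazolidin-1-yl in place of (4H-1,2,4-triazol-3-yl)amino on a saturated chain carbon bound to an aromatic carbon and a saturated chain carbon. Among the compounds with values here, only one measured step speaks to this change, the step of a 2.0-fold higher number from compound 1 to compound 2 (0.30 log units; within the scatter), in which a group on the same saturated chain carbon was exchanged for another small ring-bearing group without any shift beyond the scatter. A second exchange of the group at that carbon is therefore expected to behave similarly, with the step of a 1.4-fold higher number from compound 2 to compound 3 (0.13 log units; within the scatter) expected to stay within, or only just beyond, the scatter in this assay. Compound 3 is estimated at 30 nM, with a range from 10 nM to 100 nM.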

Compound 3, inhibition constant: 9.1 nM
Estimate against measurement, compound 3: 3.3-fold (0.52 log units) above; the whole stated range lies above it.
By their numbers in this assay, from the lowest: compounds 3, 1 and 2 (each within the scatter of the next, the first and the last beyond it).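

Going by these compounds alone, at the saturated chain carbon bound to an aromatic carbon and a saturated chain carbon, putting 2-oxoimidazolidin-1-yl in place of (4H-1,2,4-triazol-3-yl)amino gives the first step beyond the scatter in this assay (a 2.4-fold lower number from compound 2 to compound 3 (0.38 log units; beyond the scatter)), though a modest one. The new group has a non-aromatic ring and fewer hydrogen-bond donors and acceptors than the group it replaces, so among these compounds neither an aromatic ring in this group nor those extra donors and acceptors are needed for a number this low; against the (1H-imidazol-2-yl)methyl group of compound 1 the exchange gives a 1.2-fold lower number from compound 1 to compound 3 (0.08 log units; within the scatter), and those two compounds cannot be told apart. Nothing measured alongside these numbers offers an explanation for the difference between compound 2 and compound 3.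

The compounds shown leave open whether a ring is needed on this carbon at all, since a plain amine or a carboxylic acid there could give a very different number. They also leave open whether the 2-oxoimidazolidin-1-yl group would keep this number with a methyl group added to it.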